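A few compounds are considered here, and "the series" means these few. Any claim that something is new, unique, unknown or untested is made for them only; others in the source may bear on it.

Measured so far:
compound 1 `COc1ccc(/C=C/[C@H]2CC=CC(=O)O2)cc1` — > 100000 nM
compound 2 `O=C1C=CC[C@H](/C=C/C2CCCCC2)O1` — 29000 nM

In a functional assay on HBL-100 cells (Homo sapiens) for antiproliferative activity, read by luminescence and CellTiter-Glo, with a stated time of 48 h (a higher number here means a weaker inhibitor, a lower number a stronger inhibitor), compound 1 stands at the limit of > 100000 nM in this assay, at which 1 of the 2 values shown sits, which is a limit of the measurement and not a number. Compound 2 gives a number in this assay, 29000 nM. Compound 3 `O=C1C=CC[C@H](/C=C/c2ccc(F)cc2)O1` has not yet been measured there. It differs from compound 1 in one place: fluoro in place of methoxy on an aromatic carbon. Among the compounds with values here, no measured pair shows this same change, so its effect is unknown here. The step from compound 1 to compound 3 is expected to be an at least 1.6-fold lower number from compound 1 to compound 3 (0.22 log units; that floor lies within the scatter), modest at most. Compound 3 is estimated at 60000 nM, with a range from 15000 nM to 200000 nM.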

Compound 3, half-maximal inhibitory concentration: 14100 nM
Beside the measured number, compound 3's estimate is 4.3-fold (0.63 log units) above it; measured number outside the range, below it.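

In this assay, fluoro in place of methoxy on an aromatic carbon, para to a group of 9 heavy atoms, gives an at least 7.0-fold lower number from compound 1 to compound 3 (0.85 log units; beyond the scatter). Within the data shown here, this is the first sign that the group at this position matters for activity against these cells. The true size of the step stays unknown, as compound 1 has only a limit of the assay and not a number: the limit of > 100000 nM in this assay, at which 1 of the 3 values shown sits.

From the compounds shown here alone, whether the change comes from adding fluoro or from losing methoxy remains open. So does the effect of other groups here, such as a chlorine atom, an amine or a carboxylic acid.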